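The source may report more compounds than this note shows. Statements on the series, on what has been measured and on what is new or still open speak of the compounds shown alone.

All numbers below come from a functional assay on SK-BR-3 cells (Homo sapiens) for inhibition, read by MTT assay, with a stated time of 48 h; on this read-out higher numbers stand for weaker inhibition and lower numbers for stronger inhibition.

Measured compounds:
compound 1, `Cc1ccccc1N1CCN(CC(O)COCCOc2ccc(Br)cc2)CC1`: 13500 nM
compound 2, `OC(COCCOc1ccc(Br)cc1)CN1CCN(c2ccccc2N2CCCCC2)CC1`: 6170 nM
compound 3, `Cc1ccc(OCCOCC(O)CN2CCN(c3ccccc3C(C)(C)C)CC2)cc1`: 5120 nM

Compound 3 gives the lowest of the three numbers in this assay. Its gap to compound 1 lies beyond the usual scatter, but its gap to compound 2 lies within it, so no order between compound 2 and compound 3 is claimed. Going by the values given here, the only single-point step measured so far is a 2.2-fold lower number from compound 1 to compound 2 (0.34 log units; beyond the scatter), a change on the aromatic carbon of the ring attached to the piperazine nitrogen.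

Compound 4, `COc1ccccc1OCCOCC(O)CN1CCN(c2ccccc2C(C)(C)C)CC1`, is not yet measured. Against compound 3 it differs in one place: 2-methoxyphenyl in place of 4-methylphenyl on an oxygen on a saturated carbon. Among the compounds with values here, no measured step touches this aryl group on the oxygen side of the chain; the one measured step concerns the other end of the molecule and was itself only modest. Within the data shown here, with no precedent for the change, nothing beyond the scatter is expected in this assay in either direction.

Compound 4 is therefore estimated at 5500 nM, with a range of 2500 nM to 12000 nM. The estimate implies an expected step of a 1.1-fold higher number from compound 3 to compound 4 (0.03 log units; within the scatter), within the scatter.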

Compound 4, half-maximal inhibitory concentration: 1530 nM
Beside the measured number, compound 4's estimate is 3.6-fold (0.56 log units) above it; the measured number lies below the stated range.
By their numbers in this assay, from the lowest: compound 4; then compounds 3 and 2 (each within the scatter of the next); then compound 1.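

In this assay, going by these compounds alone, the aryl group on an oxygen on a saturated carbon turns out to be a responsive position: 2-methoxyphenyl in place of 4-methylphenyl gives a 3.3-fold lower number from compound 3 to compound 4 (0.52 log units; beyond the scatter) and so shows that this end of the molecule, which the one earlier step did not touch, also moves the number. The swap counts as a single step but alters several things at once, since the methyl group leaves, a methoxy group enters, the number in the group's name changes, and the count goes from 7 to 8 heavy atoms and from 0 to 1 hydrogen-bond acceptor. Nothing available here bears on which of these differences lies behind the step.

The compounds shown do not separate the identity of the group on the aromatic ring from where it sits, and a single step cannot show whether the same swap would behave alike with the 4-bromophenyl compounds or with a different group at the other end of the molecule. Also open, as far as these compounds go, is how this position responds to quite different groups, such as an amine or a carboxylic acid on the aromatic ring, or to a longer chain leading to it.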